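The source may hold more compounds than are shown below. What is called first, only, known or untested is meant among the compounds shown, and "the series" means these compounds.

Among the measured compounds shown here, compound 1, `NC(=O)c1c(NC(=O)c2ccccc2Cl)sc2c1CCN(Cc1ccccc1)C2`, is a weak inhibitor in a functional assay on HeLa cells (Homo sapiens) for antiproliferative activity, with a stated time of 24 h; a lower number here means a stronger inhibitor, a higher number a weaker inhibitor: compound 1 gives 38400 nM, and this is the only numerical value available here. Compound 2, `Cc1ccc(C(=O)Nc2sc3c(c2C(N)=O)CCN(Cc2ccc(Cl)cc2Cl)C3)cc1`, differs from compound 1 at more than one place. In this assay compound 2 reaches only the limit of > 50000 nM, which is a boundary of the measurement and not a number. Given (the limit of > 50000 nM in this assay, at which 1 of the 2 values shown sits), compound 1 stands as the sole measured figure, and that figure itself lies not far from the boundary. Compound 3, `NC(=O)c1c(NC(=O)c2ccccc2Cl)sc2c1CCN(C(=S)Nc1ccccc1Br)C2`, keeps the core of compound 1 and changes one place: a group of 10 heavy atoms (7 carbon, 1 nitrogen, 1 sulfur, 1 bromine; one six-membered aromatic ring of carbon only) in place of a group of 7 heavy atoms (7 carbon; one six-membered aromatic ring of carbon only), on an amine nitrogen in a ring. For the measured compounds named here, no pair of measured compounds that differ in only one place exists here, so the size of such a step cannot be read from data. Because compound 1 gives 38400 nM and the rest of the molecule is unchanged, compound 3 is expected to stay weak, roughly level with compound 1 and within the scatter. Compound 3 is expected to give 30000 nM, between 8000 nM and 60000 nM, an expected step of a 1.3-fold lower number from compound 1 to compound 3 (0.11 log units; within the scatter).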

Compound 3, half-maximal inhibitory concentration: 24600 nM
Compound 3: the middle estimate sits 1.2-fold (0.09 log units) above what was measured; measured number inside the range.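

Among the compounds shown here, the step at the amine nitrogen in the ring, a 1.6-fold lower number from compound 1 to compound 3 (0.19 log units; within the scatter), is the first comparison in this assay that isolates a single place on the molecule. It shows that the benzyl group can give way to a larger group carrying sulfur, bromine, a hydrogen-bond donor and a hydrogen-bond acceptor while the two compounds remain level, so this particular swap opens no real separation at this position. Compound 3 also remains a weak inhibitor, and the measured numbers sit in the same weak range as a value that is only a limit and not a number: the limit of > 50000 nM in this assay, at which 1 of the 3 values shown sits.

Since several features entered together in this one step, the compounds shown cannot separate the part played by the bromine from that of the sulfur-containing link or the ring that carries the bromine. They also leave open whether a quite different group on this nitrogen, such as a simple methyl, a carboxylic acid or a longer chain ending in an amine, would move the number beyond the scatter.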